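The source may report more compounds than this note shows. Statements on the series, on what has been measured and on what is new or still open speak of the compounds shown alone.

Measured compounds:
Compound 1, `Nc1ncn(CCC2(N)OC(=O)C(OCc3ccccc3)=C2OCc2ccccc2)c(=O)n1`, in a functional assay on HepG2 cells (Homo sapiens) for inhibition, read by MTT assay, with a stated time of 72 h (on this read-out lower numbers stand for stronger inhibition and higher numbers for weaker inhibition), gives > 100000 nM, which is a limit of the assay and not a number.
Compound 2, `NC1(CCn2ccc(=O)[nH]c2=O)OC(=O)C(OCc2ccccc2)=C1OCc1ccccc1`, in this assay gives > 100000 nM, again a limit rather than a number.
Compound 3, `O=C1O[C@H]([C@@H](O)Cn2ccc(NC(=O)c3ccccc3)nc2=O)C(OCc2ccccc2)=C1OCc1ccccc1`, in this assay gives 62200 nM.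

Compound 2 therefore stands at the limit of this assay, and the same is true of compound 1, so the step that the two limits leave unreadable from compound 1 to compound 2 cannot be read. For the measured compounds named here, the only full number among the three belongs to compound 3, and no step connects compound 3 to compound 2 in one place.

Compound 4, `Cc1cn(CCC2(N)OC(=O)C(OCc3ccccc3)=C2OCc2ccccc2)c(=O)[nH]c1=O`, differs from compound 2 by methyl in place of hydrogen on an aromatic carbon. Going by the values given here, no measured step shows what a methyl in this position does, since the single step available is unreadable. The expectation for compound 4 is set by the limit of > 100000 nM in this assay, at which 2 of the 3 values shown sit, namely that it stays at the limit. The estimated step of a number no higher from compound 2 to compound 4 (the limit leaves the size open) is expected to be none beyond the scatter. Compound 4 is therefore estimated at 100000 nM, in a range from 40000 nM to 300000 nM.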

Compound 4, half-maximal inhibitory concentration: > 100000 nM
Compound 4: only a limit was reported (the forecaster's own chance of this, stated with the estimate: 70%); the middle value sits exactly at the limit.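

In this assay compound 4 gives > 100000 nM, which is a limit of the assay and not a number. The steps to compound 4 from compound 1 and from compound 2 cannot be read. From the compounds shown here alone, what methyl in place of hydrogen on an aromatic carbon does to the value remains open.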